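A few compounds are considered here, and "the series" means these few. Any claim that something is new, unique, unknown or untested is made for them only; others in the source may bear on it.

Measured so far in a functional assay on GBM1 cells (Homo sapiens) for antiproliferative activity, read by WST assay, with a stated time of 72 h; a lower number here means a stronger inhibitor, a higher number a weaker inhibitor:
- compound 1 `O=C(Nc1ccccc1F)Nc1cc2ncncc2cc1OCc1cccc(Cl)c1` gives 4200 nM
- compound 2 `O=C(Nc1cc2ncncc2cc1OCc1cccc(F)c1)Nc1cccc2ccccc12` gives 1300 nM

Compound 2 holds the lower of these two numbers, and compound 1 stands above it by more than the usual scatter. The next compound is compound 3 `O=C(Nc1ccccc1F)Nc1cc2ncncc2cc1OCc1cccc(F)c1`, which has 2-fluorophenyl in place of naphthalen-1-yl on an amide-type nitrogen. Among the compounds with values here, no step between measured compounds sizes this change directly. Compound 1 also carries 2-fluorophenyl and gives 4200 nM in this assay, so a move towards a higher number, a weaker inhibitor, is expected, probably just beyond the scatter. The estimated change is a 2.3-fold higher number from compound 2 to compound 3 (0.36 log units; beyond the scatter) on this reading. For compound 3 the estimated value is 3000 nM with an expected range of 1200 nM to 7500 nM in this measurement.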

Compound 3, half-maximal inhibitory concentration: 8000 nM
The estimate for compound 3 lay 2.7-fold (0.43 log units) below the measured number, outside the stated range (above it).
By their numbers in this assay, from the lowest: compound 2; then compounds 1 and 3 (each within the scatter of the next).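

In this assay, within the data shown here, 2-fluorophenyl in place of naphthalen-1-yl on the amide-type nitrogen gives a 6.2-fold higher number from compound 2 to compound 3 (0.79 log units; beyond the scatter), the first direct reading of this change, and it favours naphthalen-1-yl with the rest of the molecule unchanged. Fluoro in place of chloro on an aromatic carbon gives a 1.9-fold higher number from compound 1 to compound 3 (0.28 log units; within the scatter), which is within the scatter, so this pair sets no order between the two halogens and the group on the amide-type nitrogen is the only change here that moves the number beyond the scatter. No supporting evidence on the reason for the step is available.

An unsubstituted phenyl or a cyclohexyl on the amide-type nitrogen would be needed to separate the role of the second aromatic ring from that of the fluoro group. As far as these compounds go, whether chloro, methoxy or trifluoromethyl on that aromatic carbon changes the number alongside naphthalen-1-yl remains open.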